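This account rests on a few compounds, and the source may have more. Where it says the series, first, only, none or still open, it means among the compounds named here.

Compound 3 `c1ccc2c(c1)CCC(CNCCCNc1cnccn1)O2` gives 10 nM in an assay on isolated protein (Bos taurus) with 5-hydroxytryptamine receptor 1D (Homo sapiens) as the target (on this read-out lower numbers stand for stronger inhibition and higher numbers for weaker inhibition), level with compound 2 `c1ccc2c(c1)CCC(CNCCCNc1ccncn1)O2` at 10 nM; compound 1 `c1ccc2c(c1)CCC(CNCCCNC1=NCCN1)O2` gives 6.31 nM, and a 1.6-fold higher number from compound 1 to compound 3 (0.20 log units; within the scatter) stays within the scatter, as does a 1.6-fold higher number from compound 1 to compound 2 (0.20 log units; within the scatter). Compound 4 `c1ccc2c(c1)CCC(CNCCCNc1nccs1)O2` is not yet measured. Its change is 1,3-thiazol-2-yl in place of pyrazin-2-yl on an amine nitrogen. For the measured compounds named here, the steps that bear on it all concern the ring on that amine nitrogen: no change at the digits printed from compound 2 to compound 3 (within the scatter) and a 1.6-fold higher number from compound 1 to compound 2 (0.20 log units; within the scatter), neither reaching beyond the scatter, even where a five-membered non-aromatic ring became a six-membered aromatic one. Compound 4 is therefore expected to show no change at the digits printed from compound 3 to compound 4 (within the scatter), no step beyond the scatter in this assay. The estimate for compound 4 is 10 nM, within 4 nM to 25 nM.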

Compound 4, half-maximal inhibitory concentration: 7.94 nM
The estimate for compound 4 lay 1.3-fold (0.10 log units) above the measured number; low and high end bracket the measured number.
By their numbers in this assay, from the lowest: compounds 1, 4, 2 and 3 (each within the scatter of the next).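

In this assay a five-membered aromatic ring carrying sulfur on the amine nitrogen behaves like the rings before it: a 1.3-fold lower number from compound 3 to compound 4 (0.10 log units; within the scatter) and a 1.3-fold lower number from compound 2 to compound 4 (0.10 log units; within the scatter) both stay within the scatter, as does a 1.3-fold higher number from compound 1 to compound 4 (0.10 log units; within the scatter). Among these four compounds, then, ring size, aromaticity and the kind of hetero atom have all changed at this position without a step beyond the scatter.

As far as these compounds go, whether a phenyl or an acetyl on this amine nitrogen, or a longer chain, would keep the number level stays open. Nothing given here explains why these steps are so small.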